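The source may report more compounds than this note shows. Statements on the series, on what has been measured and on what is new or still open speak of the compounds shown alone.

Notes on the series in a functional assay on HCT-116 cells (Homo sapiens) for inhibition, read by sulforhodamine B assay, with a stated time of 72 h; a lower number here means a stronger inhibitor, a higher number a weaker inhibitor.

Compound 1 `O=C(/C=C/c1cn(-c2ccccc2)nc1-c1cccnc1)c1ccsc1` gives 1300 nM in this assay. Compound 3 `O=C(/C=C/c1cn(-c2ccccc2)nc1-c1ccncc1)c1ccsc1` gives 1100 nM. The two differ by the change (pyridin-4-yl in place of pyridin-3-yl on an aromatic carbon), and the step of a 1.2-fold lower number from compound 1 to compound 3 (0.07 log units; within the scatter) is small. Compound 2 `COc1ccc(C(=O)/C=C/c2cn(-c3ccccc3)nc2-c2cccnc2)c(OC)c1OC` gives 1100 nM; the difference between its core and the core of compound 1 is not broken down here, and the two values lie close together.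

Compound 4 `COc1ccc(C(=O)/C=C/c2cn(-c3ccccc3)nc2-c2ccncc2)c(OC)c1OC` is not yet measured. Among the measured compounds shown here, it differs from compound 2 by pyridin-4-yl in place of pyridin-3-yl on an aromatic carbon, the same kind of change as the one from compound 1 to compound 3; the place lines differ only in that the ring atom next to the site bears a large group in compound 2 and a group of 9 heavy atoms in compound 1.

For compound 4 the step from compound 2 is expected to be about a 1.1-fold lower number from compound 2 to compound 4 (0.04 log units; within the scatter), beside the measured 1.2-fold lower number from compound 1 to compound 3 (0.07 log units; within the scatter), because the earlier step of a 1.2-fold lower number from compound 1 to compound 3 (0.07 log units; within the scatter) was within the scatter. Compound 4 is therefore estimated at 1000 nM, with a range from 500 nM to 2000 nM.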

Compound 4, half-maximal inhibitory concentration: 1300 nM
Compound 4: middle estimate off by 1.3-fold (0.11 log units), on the low side, within the range that was stated.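

In this assay, pyridin-4-yl in place of pyridin-3-yl gives a 1.2-fold higher number from compound 2 to compound 4 (0.07 log units; within the scatter) on the core of compound 2, a step that lies within the scatter. Set beside the earlier step on the core of compound 1, the change carries over between these two cores with no difference that can be told from the scatter: the same change on two cores in this assay, a 1.2-fold lower number (0.07 log units; within the scatter) from compound 1 to compound 3 and a 1.2-fold higher number (0.07 log units; within the scatter) from compound 2 to compound 4, 1.4-fold (0.15 log units) apart, within the scatter of two such steps

Among the compounds shown here, this shows only that the change stayed small on both cores; it gives the change no direction, does not favour either pyridinyl group, and does not show how the change would behave on any third core.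

Open, on these data alone, is whether the reading moves at all when this place carries a group other than the two pyridinyl groups, such as pyridin-2-yl, a plain phenyl or a morpholine. Also open, as far as these compounds go, is how the series answers a change elsewhere, for instance a methyl group in place of the phenyl group on the ring nitrogen.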